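This account rests on a few compounds, and the source may have more. Where it says the series, first, only, none or still open, it means among the compounds named here.

The measured compounds and their values:

compound 1, `CCC/N=C(\NC#N)Nc1cccnc1`: 20 mg/kg
compound 2, `N#CN/C(=N\C1CCCC1)Nc1cccnc1`: 20 mg/kg

In a functional assay on the whole organism (blood, strain Wistar-Okamoto) with Rattus norvegicus as the target, with a stated time of 5 days (a lower number here means that less compound is needed, a higher number that more compound is needed for the effect), compound 2 gives 20 mg/kg and so stands level with compound 1, which in this assay gives 20 mg/kg; the step of no change at the digits printed from compound 1 to compound 2 (within the scatter) lies within the scatter. Compound 3, `N#CN/C(=N\C1CCCCC1)Nc1cccnc1`, has not yet been measured. It differs from compound 2 in one place: cyclohexyl in place of cyclopentyl on a double-bonded nitrogen. Among the compounds with values here, the only measured step that bears on this place is the one from a propyl chain to a cyclopentyl ring on the same double-bonded nitrogen, no change at the digits printed from compound 1 to compound 2 (within the scatter), which produced no change at the digits printed. The group now entering is again a saturated carbon ring, one member larger. On that basis compound 3 is expected to show no step beyond the scatter, no change at the digits printed from compound 2 to compound 3 (within the scatter), and its estimated value in this assay is 20 mg/kg, with a range from 10 mg/kg to 40 mg/kg.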

Compound 3, minimum effective dose: 20 mg/kg
Estimate against measurement, compound 3: no gap at the digits printed; the range from low to high includes it.
By their numbers in this assay, from the lowest: compounds 1, 2 and 3 (each within the scatter of the next).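

In this assay, enlarging the saturated carbon ring on the double-bonded nitrogen from cyclopentyl to cyclohexyl gives no change at the digits printed from compound 2 to compound 3 (within the scatter), so this position accepts a six-membered non-aromatic ring as well as a five-membered one. Within the data shown here, the direct comparison with the open chain gives no change at the digits printed from compound 1 to compound 3 (within the scatter), which extends the level reading to a propyl chain and two carbon rings, where the earlier compounds offered only one chain and one ring. Nothing available explains why these groups read alike at this place.

All three groups contain carbon only, and none of them shifts the minimum effective dose beyond the scatter. Going by these compounds, it remains open whether this level would hold with a phenyl ring, an amine or a carboxylic acid at the same nitrogen.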